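The source may hold more compounds than are shown below. What is called first, only, known or untested is meant among the compounds shown, and "the series" means these compounds.

Working notes on the series.

Going by the values given here, compound 1 `Nc1cc(N)c2nc(-c3ccccc3)c(Oc3ccc(Cl)c(Cl)c3)nc2c1` is one of two compounds measured in a functional assay on UACC-257 cells (Homo sapiens) for inhibition, read by sulforhodamine B assay, with a stated time of 48 h; on this read-out lower numbers stand for stronger inhibition of growth and higher numbers for weaker inhibition of growth. In this assay compound 1 gives 87100 nM. Compound 2 `COc1cc(CNc2nc3cc(N)cc(N)c3nc2-c2ccccc2)cc(OC)c1OC` in this assay gives 10700 nM. Of the two numbers compound 1 stands highest; the nearest is compound 2, whose number is lower by a margin that lies beyond the scatter of repeated measurements. Among the compounds with values here, no step between measured compounds that differ in a single place is available, so the effect of any one change has not been isolated within the shared core.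

Compound 3 `COc1ccc(Sc2nc3cc(N)cc(N)c3nc2-c2ccccc2)cc1` is not yet measured. It differs from compound 1 by (4-methoxyphenyl)sulfanyl in place of 3,4-dichlorophenoxy on an aromatic carbon. Within the data shown here, both measured compounds keep the shared core and differ only in the group at this position, and the only comparison available, compound 1 against compound 2, shows that this position can move the number by a margin beyond the scatter. For compound 3 the expectation is a number below that of compound 1, with the step from compound 1 to compound 3 estimated at a 2.9-fold lower number from compound 1 to compound 3 (0.46 log units; beyond the scatter). The estimate for compound 3 in this assay is 30000 nM, with a range from 8000 nM to 90000 nM.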

Compound 3, concentration for total growth inhibition: < 100000 nM
Compound 3: a limit, no number; the forecaster's own chance of this, stated with the estimate: 10%; the middle value lies beyond the limit too.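

Going by these compounds alone, compound 3 gives < 100000 nM in this assay; this is a limit of the assay and not a number, so no step from compound 1 to compound 3 can be read. The compounds shown leave open whether (4-methoxyphenyl)sulfanyl in place of 3,4-dichlorophenoxy on the shared core gives a lower number, a higher one, or no change beyond the scatter.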